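Swapping a chloro for a methoxy on a shared core

The source may report more compounds than this note shows. Statements on the series, on what has been measured and on what is new or still open speak of the compounds shown alone.

Compound 1, `Clc1ccc(-c2n[nH]cc2N2CCCNCC2)cc1`, was tested in an assay on isolated protein for binding affinity to 5-hydroxytryptamine receptor 5A (Homo sapiens); a lower number here means a stronger inhibitor, a higher number a weaker inhibitor. In this assay compound 1 gives > 10000 nM, which is a limit of the assay rather than a number. Compound 2, `COc1ccccc1-c1n[nH]cc1N1CCCNCC1`, carries its methoxy on a different carbon of the same ring and was tested in the same way. In this assay compound 2 gives > 10000 nM, again a limit and not a number. For the measured compounds named here, compound 1 therefore stands at the same limit as the only other value shown, as noted in the limit of > 10000 nM in this assay, at which 2 of the 2 values shown sit.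

The unmeasured compound 3, `COc1ccc(-c2n[nH]cc2N2CCCNCC2)cc1`, differs from compound 1 in one place: methoxy in place of chloro on an aromatic carbon. Going by the values given here, no step between two numbered values is available here, so the size of this change cannot be read from a measured pair. Given that compound 1 sits at the limit, the step from compound 1 to compound 3 is expected to be a step that the limit leaves unreadable from compound 1 to compound 3, with no clear direction beyond the scatter. For compound 3 the estimate in this assay is 20000 nM, within a range from 5000 nM to 100000 nM, most likely reported again only as a limit.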

Compound 3, inhibition constant: > 10000 nM
Compound 3 was reported as a limit; the forecaster's own chance of this, stated with the estimate: 85%; the middle value does not contradict the limit.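

Compound 1 and compound 3 both stand at a limit of the assay rather than at a number, so swapping chloro for methoxy gives no step that can be read: the limit of > 10000 nM in this assay, at which 3 of the 3 values shown sit.

The compounds shown leave open which change to the shared core, if any, would give an actual number in this assay instead of a limit.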